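Cytotoxicity of a New Analogue in the Oxazole Series

The source may hold more compounds than are shown below. What is called first, only, known or untested is meant among the compounds shown, and "the series" means these compounds.

Measured compounds:
compound 1 `Fc1cccc(F)c1Cc1cnc(Nc2ccc(Oc3ccncc3)c(Cl)c2)o1` with 21000 nM
compound 2 `Clc1cccc(Cl)c1Cc1nnc(Nc2ccc(COCc3ccoc3)cc2)o1` with 21000 nM
compound 3 `Fc1cccc(F)c1Cc1cnc(Nc2ccc(Oc3ccncc3)cc2)o1` with 21000 nM

All three compounds were tested in an ADME assay on MT2 cells (Homo sapiens) for cytotoxicity, read by MTT assay; on this read-out lower numbers stand for higher toxicity in this test and higher numbers for lower toxicity in this test. Compound 1 gives 21000 nM, compound 2 gives 21000 nM and compound 3 gives 21000 nM, so compound 3 stands level with both others at the digits shown. Within the data shown here, the only step between two measured compounds that differ in one place runs from the chloro of compound 1 to the hydrogen of compound 3, with no change at the digits printed from compound 1 to compound 3 (within the scatter).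

Compound 4 `O=c1ncccn1SCCc1ccc(Nc2ncc(Cc3c(F)cccc3F)o2)cc1` has not yet been measured in this assay. It differs from compound 3 in the following way: a group of 10 heavy atoms (6 carbon, 2 nitrogen, 1 oxygen, 1 sulfur; one six-membered aromatic ring with 2 hetero atoms) in place of a group of 7 heavy atoms (5 carbon, 1 nitrogen, 1 oxygen; one six-membered aromatic ring with 1 hetero atom), on an aromatic carbon. The new group sits on an aromatic carbon of a six-membered aromatic ring of carbon only, para to a large group.

Among the measured compounds shown here, no measured step replaces the (pyridin-4-yl)oxy group, so none bears directly on this change. For the measured compounds named here, the one available step, from compound 1 to compound 3, showed no change beyond the scatter, and compound 2, with a quite different substituent on the same ring, also gives 21000 nM. Compound 4 is therefore expected to show no change at the digits printed from compound 3 to compound 4 (within the scatter), with no step beyond the scatter. The estimate for compound 4 is 21000 nM, within a range from 8000 nM to 45000 nM.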

Compound 4, half-maximal cytotoxic concentration: > 100000 nM
Compound 4: a limit, no number; the forecaster's own chance of this, stated with the estimate: 30%; middle value at least 4.7-fold (0.67 log units) from the limit.
By their numbers in this assay, from the lowest: compounds 1, 2 and 3 (each within the scatter of the next). At a limit, above all of these: compound 4.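

In this assay, the position on an aromatic carbon of a six-membered aromatic ring of carbon only, para to a large group, now shows a change beyond the scatter: putting the group of 10 heavy atoms, with its six-membered aromatic ring with 2 hetero atoms, in place of (pyridin-4-yl)oxy gives an at least 4.7-fold higher number from compound 3 to compound 4 (0.67 log units; beyond the scatter). Among these compounds, the only earlier step, hydrogen in place of chloro on the same carbon-only ring, gave no change at the digits printed from compound 1 to compound 3 (within the scatter), whereas this change moves the read-out towards lower toxicity in this test. The result for compound 4 is a limit and not a number: the limit of > 100000 nM in this assay, at which 1 of the 4 values shown sits.

The compounds shown do not tell which part of the entering group carries this step: the sulfur, the chain that links it to the ring of carbon only, or the ring with 2 hetero atoms. They also leave open how a group such as an amine, a carboxylic acid or a longer chain at this position would read in this assay.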